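Adding a 4-(dimethylamino)butyl chain to compound 1

A few compounds are considered here, and "the series" means these few. Any claim that something is new, unique, unknown or untested is made for them only; others in the source may bear on it.

Measured in a functional assay on A549 cells (Homo sapiens) for antiproliferative activity, read by MTT assay, with a stated time of 48 h; on this read-out lower numbers stand for stronger inhibition and higher numbers for weaker inhibition:
Compound 1 `Cn1c(N)c(-c2nc3ccccc3[nH]2)c2nc(C#N)c(C#N)nc21`: > 50000 nM
Compound 2 `CN1CCN(CCCn2c(N)c(-c3nc4ccccc4[nH]3)c3nc(C#N)c(C#N)nc32)CC1`: 5750 nM

The entry for compound 1 is a limit and not a number: the limit of > 50000 nM in this assay, at which 1 of the 2 values shown sits. Compound 3 `CN(C)CCCCn1c(-c2c(N)n(C)c3nc(C#N)c(C#N)nc23)nc2ccccc21` differs from it by 4-(dimethylamino)butyl in place of hydrogen on an aromatic nitrogen. Among the compounds with values here, one measured step bears on this change: an at least 8.6-fold lower number from compound 1 to compound 2 (0.93 log units; beyond the scatter). That step also adds a chain, but at a different place, so it is only a rough guide. A step in the same direction and of similar size is therefore expected in this assay, and the expected change is an at least 6.2-fold lower number from compound 1 to compound 3 (0.79 log units; beyond the scatter). For compound 3 the estimate is 8000 nM, with an expected range of 2000 nM to 40000 nM.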

Compound 3, half-maximal inhibitory concentration: 11200 nM
Estimate against measurement, compound 3: 1.4-fold (0.15 log units) below; the range from low to high includes it.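

In this assay, a chain on the aromatic nitrogen also goes with a lower number: an at least 4.4-fold lower number from compound 1 to compound 3 (0.64 log units; beyond the scatter). This nitrogen, which carries only hydrogen in compound 1, therefore accepts 4-(dimethylamino)butyl with a gain in activity, so the chain of compound 2 is not the only added chain to give a measurable value. The true size of this step remains unknown, as the entry for compound 1 is a limit: the limit of > 50000 nM in this assay, at which 1 of the 3 values shown sits.

From the compounds shown here alone, it remains open whether the terminal dimethylamino group matters at this nitrogen. A plain butyl chain, a shorter chain or a chain ending in 4-methylpiperazine could each settle that.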